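This account rests on a few compounds, and the source may have more. Where it says the series, first, only, none or still open, it means among the compounds named here.

Of the compounds shown here, three share one core and have been tested in an ADME assay on MT4 cells (Homo sapiens) for cytotoxicity, read by MTT assay, with a stated time of 5 days; on this read-out lower numbers stand for higher toxicity in this test and higher numbers for lower toxicity in this test. Compound 1 `N#C/C=C/c1ccc(C(NC2CC2)c2ccnc(Nc3ccc(C#N)cc3)n2)cc1` gives 56100 nM. Compound 2 `CCCNC(c1ccc(C#N)cc1)c1ccnc(Nc2ccc(C#N)cc2)n1` gives 34900 nM. Compound 3 `CCNC(c1ccc(/C=C/C#N)cc1)c1ccnc(Nc2ccc(C#N)cc2)n1` gives 37300 nM, a number that sits close to compound 2 and to compound 1, with all three numbers within the usual scatter of one another, so none of them can be called more or less toxic than the others.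

Among the compounds with values here, the one single-point change among the measured compounds, a 1.5-fold lower number from compound 1 to compound 3 (0.18 log units; within the scatter), shifts the number only within the scatter.

Compound 4 `CCNC(c1ccc(C#N)cc1)c1ccnc(Nc2ccc(C#N)cc2)n1` is not yet measured. It differs from compound 3 in one place: cyano in place of 2-cyanoethenyl on an aromatic carbon. Within the data shown here, no measured step bears directly on this change, since the only measured step concerns a group on an amine nitrogen. Compound 2 already carries the cyano group that enters here, though it differs from compound 3 in a second place as well; its number and that of compound 3 are within the scatter of each other, so this pair shows no sign that the cyano group moves the number.

The expectation for compound 4 is therefore a step of a 1.1-fold lower number from compound 3 to compound 4 (0.03 log units; within the scatter), not beyond the scatter. Compound 4 is estimated at 35000 nM, with a likely range from 17000 nM to 70000 nM.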

Compound 4, half-maximal cytotoxic concentration: 158000 nM
Beside the measured number, compound 4's estimate is 4.5-fold (0.65 log units) below it, and the stated range ends below it.
By their numbers in this assay, from the lowest: compounds 2, 3 and 1 (each within the scatter of the next); then compound 4.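

In this assay, within the data shown here, swapping 2-cyanoethenyl for cyano on this aromatic carbon, para to a large group, gives a 4.2-fold higher number from compound 3 to compound 4 (0.63 log units; beyond the scatter), the first change at this position to be read directly, and it points to lower toxicity in this test. The chain on the amine nitrogen also matters once cyano is in place: hydrogen in place of methyl on a saturated chain carbon, two bonds along the chain from that nitrogen, gives a 4.5-fold higher number from compound 2 to compound 4 (0.66 log units; beyond the scatter), whereas the earlier step on that nitrogen, with a different change and 2-cyanoethenyl on the aromatic ring, stayed within the scatter. Nothing available explains either step, so the numbers record the size of these changes but not what lies behind them.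

From the compounds shown here alone, what a chloro group or a carboxylic acid on the same aromatic carbon would give remains open, so it cannot yet be said how far this result extends beyond cyano and 2-cyanoethenyl. Also open, going by these compounds, is whether cyclopropyl on the amine nitrogen, paired with cyano, would give a number like that of compound 4.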